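Swapping the Amide Chain on the Sugar-Free Core

This account rests on a few compounds, and the source may have more. Where it says the series, first, only, none or still open, it means among the compounds named here.

Four compounds share one core. Compound 1 `CC(C)=CCC(=O)Nc1ccn([C@H]2CC[C@H](O)[C@@H](C)O2)c(=O)n1` has the simplest form of it, with a (3-methylbut-2-en-1-yl)carbonyl group on the amide nitrogen. In a functional assay on HCT-116 cells (Homo sapiens) for cytotoxicity, read by sulforhodamine B assay, with a stated time of 24 h (on this read-out lower numbers stand for stronger inhibition and higher numbers for weaker inhibition), compound 1 gives > 20000 nM, which is a limit of the assay rather than a measured number. Among the compounds with values here, compound 2 `CC(C)CCC(=O)Nc1ccn([C@H]2CC[C@H](O[C@H]3O[C@H](C)[C@@H](N(C)C)[C@H](O)[C@H]3O)[C@@H](C)O2)c(=O)n1` and compound 3 `CC(C)C(=O)Nc1ccc(C(=O)Nc2ccn([C@H]3CC[C@H](O[C@H]4O[C@H](C)[C@@H](N(C)C)[C@H](O)[C@H]4O)[C@@H](C)O3)c(=O)n2)cc1` both carry an additional ring-containing group that compound 1 lacks; in this assay compound 2 gives 390 nM and compound 3 gives 6630 nM, and the one measured step, a 17-fold higher number from compound 2 to compound 3 (1.23 log units; beyond the scatter), concerns a different change at the amide carbonyl and is not the change examined here. Compound 4 `CC(C)C(=O)Nc1ccn([C@H]2CC[C@H](O)[C@@H](C)O2)c(=O)n1` differs from compound 1 by isopropyl in place of 3-methylbut-2-en-1-yl on a carbonyl carbon. Within the data shown here, no measured step follows this exchange on the core of compound 1, so the only guide is the limit of > 20000 nM in this assay, at which 1 of the 3 values shown sits. Compound 4 is therefore expected to remain near that limit, with an estimated value of 30000 nM and a range of 10000 nM to 100000 nM. The expected step is a step that the limit leaves unreadable from compound 1 to compound 4, that is, no change beyond the scatter.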

Compound 4, half-maximal inhibitory concentration: > 20000 nM
Compound 4: only a limit was reported (the forecaster's own chance of this, stated with the estimate: 80%); the middle value does not contradict the limit.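

Compound 1 and compound 4 both stand at a limit rather than at a measured number, so no step can be read between them in this assay: the limit of > 20000 nM in this assay, at which 2 of the 4 values shown sit.

The compounds shown leave open how isopropyl and 3-methylbut-2-en-1-yl would compare on a core giving measured numbers, such as that of compound 2.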